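Swapping Dimethylamino for Methoxy on the Other Ring

The source may report more compounds than this note shows. Statements on the series, on what has been measured and on what is new or still open speak of the compounds shown alone.

Compound 1, `CN(C)c1ccc(/C=C/C(=O)c2ccc(N(C)C)cc2O)cc1`: 12100 nM in an assay on isolated protein for inhibition of Amine oxidase [flavin-containing] B (Homo sapiens); a higher number here means a weaker inhibitor, a lower number a stronger inhibitor
Compound 2, `COc1ccc(/C=C/C(=O)c2ccc(N(C)C)cc2O)cc1`: 13300 nM in this assay

Of the compounds shown here, two have been measured so far. In this assay compound 1 gives 12100 nM, the lowest of the two numbers, and compound 2 gives 13300 nM; the step of a 1.1-fold higher number from compound 1 to compound 2 (0.04 log units; within the scatter) is within the scatter, so these two values cannot be told apart.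

The new compound is compound 3, `COc1ccc(C(=O)/C=C/c2ccc(N(C)C)cc2)c(O)c1`. It differs from compound 1 by methoxy in place of dimethylamino on an aromatic carbon. This is the same kind of exchange that separates compound 1 from compound 2, only carried out on the other ring of the shared core, the ring that also carries the hydroxy group.

Going by the values given here, the only measured step that bears on this change is a 1.1-fold higher number from compound 1 to compound 2 (0.04 log units; within the scatter), and it was within the scatter. The expectation for compound 3 is therefore a step no larger than the scatter in this assay, in no particular direction, so that the step of a 1.1-fold higher number from compound 1 to compound 3 (0.03 log units; within the scatter) is expected to be small. Compound 3 is estimated at 13000 nM, with a range from 5000 nM to 35000 nM.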

Compound 3, half-maximal inhibitory concentration: 210 nM
The estimate for compound 3 lay 62-fold (1.79 log units) above the measured number, and the stated range ends above it.
By their numbers in this assay, from the lowest: compound 3; then compounds 1 and 2 (each within the scatter of the next).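

In this assay, placing methoxy instead of dimethylamino on the aromatic carbon meta to a hydroxy group and para to a large group gives a 58-fold lower number from compound 1 to compound 3 (1.76 log units; beyond the scatter) and so a much stronger inhibitor. The same exchange on the other ring gave a 1.1-fold higher number from compound 1 to compound 2 (0.04 log units; within the scatter) and no readable change, so in these compounds the effect of this exchange depends strongly on where it is made. Nothing available here accounts for the difference between the two places.

As far as these compounds go, it remains open whether methoxy itself matters at this position or whether the loss of dimethylamino is enough, which a plain hydrogen, a fluorine or an ethoxy group in the same place would help to separate. From the compounds shown here alone, it is also open whether the other ring, which carries dimethylamino in compound 3, would tolerate methoxy or a small amine such as methylamino once this position already holds methoxy.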